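This account rests on a few compounds, and the source may have more. Where it says the series, first, only, none or still open, it means among the compounds named here.

Measured so far in an assay for inhibition of Dihydrofolate reductase (Homo sapiens); a higher number here means a more potent compound, by a factor of ten per unit of this negative logarithm, a lower number a less potent compound:
compound 1, `Sc1nc(S)c2cc(Sc3ccc4ccccc4c3)ccc2n1` — 5.05
compound 2, `Nc1nc(N)c2cc(CNC(=O)c3ccc4ccccc4c3)ccc2n1` — 7
compound 3, `Nc1nc(O)nc2ccccc12` — 4.02

Compound 1 stands second of the three numbers in this assay. Its nearest neighbour is compound 3, which lies lower by a margin beyond the scatter; furthest from it is compound 2, which lies higher, again beyond the scatter. Among the measured compounds shown here, none of these three pairs differs in one place only, so no single step between measured compounds can be read from them; the values show only that the diamino compound 2 is the most potent of the three and the amino–hydroxy compound 3 the least.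

Compound 4, `Nc1nc(S)c2cc(Sc3ccc4ccccc4c3)ccc2n1`, is the next to be measured in this assay. It is derived from compound 1 by amino in place of sulfanyl on an aromatic carbon. The sulfanyl on the other aromatic carbon of the core and the naphthyl-bearing sulfanyl side arm stay as in compound 1.

For the measured compounds named here, compound 4 is expected to gain over compound 1, the step from a number 0.65 log units higher from compound 1 to compound 4 (beyond the scatter) being estimated as moderate and upward, because compound 2 gives 7 as the only compound here carrying amino at that position between the two ring nitrogens, though compound 2 also differs elsewhere. The estimate for compound 4 is 5.7, with a range from 4.9 to 6.5.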

Compound 4, logarithm of the reciprocal of the active concentration, log(1/C): 6.64
Compound 4: the middle estimate sits 0.94 log units below what was measured; the whole stated range lies below it.
By their numbers in this assay, from the lowest: compound 3; then compound 1; then compound 4; then compound 2.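

In this assay, among the compounds shown here, the position between two ring nitrogen atoms proves sensitive: amino in place of sulfanyl on this aromatic carbon gives a number 1.59 log units higher from compound 1 to compound 4 (beyond the scatter) and this is the first single-place step. The exchange is one heavy atom for one heavy atom, with hydrogen-bond donor and acceptor counts and net charge the same on both sides, so these counts do not separate the two groups. The naphthyl-bearing sulfanyl side arm and the other sulfanyl on the core stay fixed, which places the whole step on this one exchange.

Still open, on these data alone, is whether a methylamino or a methyl group at this position would hold the gain, and whether amino in place of the remaining sulfanyl would add to it. Nothing shown gives a reason for the size of this step.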